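Compound 2 to compound 3: one oxygen substituent removed

The compounds below may be only part of what the source reports. "The series", "measured", "known", "first", "only" and "open" are said of these compounds alone.

In a functional assay on PANC-1 cells (Homo sapiens) for cytotoxicity, read by MTT assay, with a stated time of 48 h, in the presence of a further agent that is not named here (a lower number here means a stronger inhibitor, a higher number a weaker inhibitor), compound 2 `O=C(NCCCOc1no[n+]([O-])c1S(=O)(=O)c1ccccc1)c1ccc2cccc(OCc3ccc(B(O)O)cc3)c2n1` gives 1690 nM and so stands within the scatter of compound 1 `O=C(c1ccc2cccc(O)c2n1)N1CCC(Oc2no[n+]([O-])c2S(=O)(=O)c2ccccc2)CC1` with 1320 nM as its number. Among the compounds with values here, these two values are the only measurements so far, and they show no separation.

Compound 3 `O=C(NCCCOc1no[n+]([O-])c1S(=O)(=O)c1ccccc1)c1ccc2cccc(O)c2n1` differs from compound 2 at one place: a hydrogen atom in place of a group of 10 heavy atoms (7 carbon, 1 boron, 2 oxygen; one six-membered aromatic ring of carbon only), on an oxygen on an aromatic ring and the rest of the structure stays the same.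

Within the data shown here, no measured pair isolates this change, so its size has no direct precedent. The nearest guide is compound 1, which carries the same hydrogen on that oxygen and gives 1320 nM in this assay as its number. A small move toward a lower number is expected, with no clear departure from the scatter. The expected size of the change is a 1.5-fold lower number from compound 2 to compound 3 (0.19 log units; within the scatter) in this assay as estimated here. For compound 3 the estimate is 1100 nM with an expected range from 450 nM to 2600 nM in this assay as the working figures.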

Compound 3, half-maximal inhibitory concentration: 860 nM
Compound 3: middle estimate off by 1.3-fold (0.11 log units), on the high side, within the range that was stated.
By their numbers in this assay, from the lowest: compounds 3, 1 and 2 (each within the scatter of the next).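

In this assay, within the data shown here, a hydrogen atom in place of the group of 10 heavy atoms, on an oxygen on an aromatic ring, gives a 2.0-fold lower number from compound 2 to compound 3 (0.29 log units; within the scatter), the first direct reading of a change at this position, and the step lies within the scatter. The oxygen therefore carries either the hydrogen or the boron-bearing group, with its six-membered aromatic ring of carbon only, without a separation that this read-out can resolve, at least on the chain and core shared by compound 2 and compound 3. The data on hand offer no measurement that explains this result or ties it to any property of the group.

Still open, as far as these compounds go, is whether any group on this oxygen moves the number beyond the scatter: a methyl group, or a benzyl group without boron, would show whether the size of the group or the boron itself matters in this assay. Also open, from the compounds shown here alone, is whether the same step stays within the scatter with a longer chain in place of the chain of compound 3, or with the boron-bearing group on the core of compound 1.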